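The compounds below may be only part of what the source reports. "The series", "measured", "known", "first", "only" and "open" are said of these compounds alone.

Within the data shown here, in a functional assay on MV4-11 cells (Homo sapiens) for antiproliferative activity (a lower number here means a stronger inhibitor, a higher number a weaker inhibitor), compound 1 `NC(=O)c1c(NC(=O)C2CC2)sc2c1CCCC2` gives 1200 nM, the higher of the two numbers measured so far, and compound 2 `Cc1ccc(C(=O)Nc2sc3c(c2C(N)=O)CCCC3)cc1` gives 450 nM. Compound 3 `NC(=O)c1c(NC(=O)c2ccc(Cl)cc2)sc2c1CCCC2` differs from compound 1 as follows: 4-chlorophenyl in place of cyclopropyl on a carbonyl carbon. Among the measured compounds shown here, the one measured step that bears on this change is a 2.7-fold lower number from compound 1 to compound 2 (0.43 log units; beyond the scatter), a modest one in which 4-methylphenyl takes the place of cyclopropyl on the same carbonyl carbon. A modest step of similar size towards a lower number is therefore expected in this assay. The expected step is a 2.9-fold lower number from compound 1 to compound 3 (0.46 log units; beyond the scatter). For compound 3 the estimated value is 420 nM, with an expected range of 150 nM to 1100 nM.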

Compound 3, half-maximal inhibitory concentration: 1400 nM
For compound 3 the middle estimate is 3.3-fold (0.52 log units) below the measured one; measured number outside the range, above it.
By their numbers in this assay, from the lowest: compound 2; then compounds 1 and 3 (each within the scatter of the next).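

In this assay, the step of a 1.2-fold higher number from compound 1 to compound 3 (0.07 log units; within the scatter) for 4-chlorophenyl in place of cyclopropyl shows that an aromatic ring on this carbonyl carbon does not by itself bring the lower number seen with compound 2. The step of a 3.1-fold higher number from compound 2 to compound 3 (0.49 log units; beyond the scatter) for chloro in place of methyl shows that the group on that aromatic ring decides the outcome here. No measurement at hand explains this difference between chloro and methyl. The compounds shown leave open whether plain phenyl, or a methoxy or an amine on the ring in place of methyl, would give a number like that of compound 2 or that of compound 3.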